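The compounds below may be only part of what the source reports. "The series", "measured", "known", "first", "only" and "open" are said of these compounds alone.

Compound 1 `Cc1cc(NC(=O)Nc2ccccc2N)c2ccccc2n1` gives 51800 nM in a physicochemical assay for solubility, at pH 7.4; a lower number here means a less soluble compound, a higher number a more soluble compound.
Compound 2 `Cc1cc(NC(=O)Nc2ccc(F)cc2)c2ccccc2n1` gives 3700 nM in this assay.
Compound 3 `Cc1cc(NC(=O)Nc2ccc(F)cc2F)c2ccccc2n1` gives 3000 nM in this assay.

Compound 2 stands second highest of these three numbers: compound 3 sits within the scatter of it, while compound 1 stands well apart, as the step of a 14-fold lower number from compound 1 to compound 2 (1.15 log units; beyond the scatter) shows. Compound 4 `Cc1cc(NC(=O)Nc2ccc(C(=O)O)cc2)c2ccccc2n1` has not been measured. It differs from compound 2 in one place: carboxy in place of fluoro on an aromatic carbon. For the measured compounds named here, no measured step exchanges a fluoro for a carboxy, so the two steps seen can only guide loosely. The step of a 1.2-fold lower number from compound 2 to compound 3 (0.09 log units; within the scatter), a fluoro in place of a hydrogen, is within the scatter. Because the step of a 14-fold lower number from compound 1 to compound 2 (1.15 log units; beyond the scatter) was large when a group carrying a hydrogen-bond donor left, and the change to compound 4 brings a hydrogen-bond donor and a hydrogen-bond acceptor in, a step to a higher number beyond the scatter is expected, namely a 16-fold higher number from compound 2 to compound 4 (1.21 log units; beyond the scatter). Compound 4 is therefore estimated at 60000 nM in this assay, within a range of 10000 nM to 400000 nM.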

Compound 4, solubility: 9300 nM
Estimate against measurement, compound 4: 6.5-fold (0.81 log units) above; the measured number lies below the stated range.
By their numbers in this assay, from the lowest: compounds 3 and 2 (each within the scatter of the next); then compound 4; then compound 1.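

The earlier compounds shown here showed only a fluoro replacing a hydrogen on an aromatic carbon, and that step stayed within the scatter, so they did not show how much the number responds when the fluoro para to a large group is itself exchanged. In this assay carboxy in place of fluoro gives a 2.5-fold higher number from compound 2 to compound 4 (0.40 log units; beyond the scatter) and this modest step lies beyond the scatter, so the group at this carbon does make a measurable difference. Nothing shown here explains why the step has this size.

As far as these compounds go, whether a methyl ester or a primary amide at this carbon would shift the number as far as carboxy does remains open. So does whether a single fluoro-to-carboxy exchange on this core predicts what other acids, such as a longer chain ending in a carboxylic acid, would do.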